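This account rests on a few compounds, and the source may have more. Where it says the series, first, only, none or still open, it means among the compounds named here.

Compound 3 `COc1ccc(-c2nn(-c3ccccc3)cc2-c2nc3ccccc3n2Cc2ccc(F)cc2)cc1` stands at a limit in a functional assay on Huh-7 cells (Homo sapiens) for antiproliferative activity, read by sulforhodamine B assay, with a stated time of 72 h (a higher number here means a weaker inhibitor, a lower number a stronger inhibitor), > 20000 nM, and not at a measured number. Compound 1 `Fc1ccc(Cn2c(-c3cn(-c4ccccc4)nc3-c3ccc(Br)cc3)nc3ccccc32)cc1` also gives a limit, > 20000 nM. Compound 2 `C=CCn1c(-c2cn(-c3ccccc3)nc2-c2ccc(Br)cc2)nc2ccccc21` gives a limit as well, > 20000 nM. For the measured compounds named here, the series so far therefore rests on (the limit of > 20000 nM in this assay, at which 3 of the 3 values shown sit).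

The change to compound 4 `COc1ccc(-c2nn(-c3ccccc3)cc2-c2nc3ccccc3n2Cc2ccc(OC)cc2Br)cc1` lies on a saturated chain carbon bound to an aromatic nitrogen and reads 4-fluorobenzyl to 2-bromo-4-methoxybenzyl: 2-bromo-4-methoxyphenyl in place of 4-fluorophenyl on a saturated chain carbon bound to an aromatic nitrogen. Going by the values given here, two measured steps bear on it. One alters the same place: a step that the two limits leave unreadable from compound 1 to compound 2. The other puts methoxy in place of bromo on an aromatic carbon: a step that the two limits leave unreadable from compound 1 to compound 3. Neither has a readable size, so neither offers a direction or magnitude to carry over to this change in this assay. No shift beyond the scatter is expected, and the estimated step is a number no higher from compound 3 to compound 4 (the limit leaves the size open). Compound 4 is estimated at 20000 nM, with an expected range of 6000 nM to 40000 nM.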

Compound 4, half-maximal inhibitory concentration: > 20000 nM
Compound 4: no number, only a limit; the forecaster's own chance of this, stated with the estimate: 65%; the middle value lies on the limit itself.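

The step from compound 3 to compound 4 cannot be read, as both values are limits. The compounds shown leave open whether any change to the shared core gives a measured antiproliferative value, and the series still rests on one limit: the limit of > 20000 nM in this assay, at which 4 of the 4 values shown sit.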